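The compounds below may be only part of what the source reports. "The series", "measured", "known", "first", "only" and "open" are said of these compounds alone.

Measured so far:
Compound 1 `COc1cc(Cl)cc(-c2nn(-c3cccc(NC(=O)c4ccc(Cl)c(Cl)c4)c3)cc2-c2ccncc2)c1` in a functional assay on T47D cells (Homo sapiens) for inhibition, read by sulforhodamine B assay, with a stated time of 48 h, tested at 10 uM; a lower number here means a stronger effect, a higher number a weaker effect of the compound at the concentration tested: 63.2%
Compound 2 `COc1cc(Cl)cc(-c2nn(-c3cccc(NC(=O)Nc4cccc(C(F)(F)F)c4)c3)cc2-c2ccncc2)c1` in this assay: -0.45%

Compound 2 stands lowest of the two numbers; its nearest neighbour is compound 1, and the step of a number 63.7 percentage points lower from compound 1 to compound 2 (beyond the scatter) is beyond the scatter. Compound 3 `COc1cc(Cl)cc(-c2nn(-c3cccc(NC(=O)c4cccc(C(F)(F)F)c4)c3)cc2-c2ccncc2)c1` has not yet been measured in this assay. Relative to compound 2, the difference is 3-(trifluoromethyl)phenyl in place of (3-(trifluoromethyl)phenyl)amino on a carbonyl carbon. Going by the values given here, the single measured step that bears on this change is the one from compound 1 to compound 2, where (3-(trifluoromethyl)phenyl)amino took the place of 3,4-dichlorophenyl on a carbonyl carbon and the read-out fell by a large amount. The change from compound 2 to compound 3 undoes that (3-(trifluoromethyl)phenyl)amino on the carbonyl carbon, so a large step upward in this assay is expected, estimated as a number 50.5 percentage points higher from compound 2 to compound 3 (beyond the scatter). Compound 3 is therefore expected to give about 50% in this assay, with a range from 20% to 80%.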

Compound 3, a percentage reported as activity, at one concentration (the size of the read-out at that concentration, not a potency): 36.6%
Compound 3: middle estimate off by 13.4 percentage points, on the high side, within the range that was stated.
By their numbers in this assay, from the lowest: compound 2; then compound 3; then compound 1.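

The earlier step changed the aryl group and added the amino nitrogen at once; with 3-(trifluoromethyl)phenyl kept in place, a number 37.1 percentage points higher from compound 2 to compound 3 (beyond the scatter) shows that the nitrogen on the carbonyl carbon matters on its own in this assay. The a number 26.6 percentage points lower from compound 1 to compound 3 (beyond the scatter) shows that the aryl group also matters without that nitrogen, with 3-(trifluoromethyl)phenyl giving the stronger effect of the two groups on the carbonyl carbon. No measurement is available that explains either step.

Going by these compounds, it remains open whether the amino nitrogen has the same effect with another aryl group, such as (3,4-dichlorophenyl)amino on the carbonyl carbon. On these data alone, it is also open whether a methylene or an oxygen atom in that place would match the amino group, or whether the nitrogen itself is needed.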